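A methoxy group on a phenyl ring: what to expect

A few compounds are considered here, and "the series" means these few. Any claim that something is new, unique, unknown or untested is made for them only; others in the source may bear on it.

Compound 1 `Cc1ccc2nc(NC(c3cn(-c4ccccc4)nc3-c3cccc(Cl)c3)c3c(O)ccc4ccccc34)sc2c1`: 45400 nM 
Compound 2 `Oc1ccc2ccccc2c1C(Nc1nc2ccccc2s1)c1cn(-c2ccccc2)nc1-c1ccccc1`: 36200 nM 

In a functional assay on A549 cells (Homo sapiens) for antiproliferative activity, read by MTT assay, with a stated time of 48 h (a higher number here means a weaker inhibitor, a lower number a stronger inhibitor), compound 2 gives 36200 nM and lies within the usual scatter of compound 1, so the two numbers cannot be ranked. Compound 3 `COc1ccc(-c2nn(-c3ccccc3)cc2C(Nc2nc3ccccc3s2)c2c(O)ccc3ccccc23)cc1` has not been measured yet. It keeps the shared core of compound 2 and turns a phenyl into 4-methoxyphenyl, with methoxy in place of hydrogen on an aromatic carbon para to a large group. Within the data shown here, no measured pair shows this change alone. Compound 1 differs from compound 2 in more than one place, yet compound 1 gives 45400 nM and stays within the scatter, so no shift beyond the scatter is expected in this assay in either direction. The expected change is a 1.2-fold lower number from compound 2 to compound 3 (0.08 log units; within the scatter) and should remain small. Compound 3 is estimated at 30000 nM with an expected range of 12000 nM to 70000 nM for the measurement.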

Compound 3, half-maximal inhibitory concentration: 26200 nM
The estimate for compound 3 lay 1.1-fold (0.06 log units) above the measured number; the range from low to high includes it.
By their numbers in this assay, from the lowest: compounds 3, 2 and 1 (each within the scatter of the next).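

Among these compounds, compound 3 gives the first view of this change on its own: in this assay, placing methoxy on an aromatic carbon para to a large group gives a 1.4-fold lower number from compound 2 to compound 3 (0.14 log units; within the scatter) and so no ranking of the two compounds. At this position, then, going from phenyl to 4-methoxyphenyl adds two heavy atoms and a hydrogen-bond acceptor without moving the number beyond what repeat measurements could produce. Nothing available explains this result.

Methoxy is the only added group seen at this position, so it remains open whether an amine, a carboxylic acid or a longer chain such as butoxy on the same carbon would shift the number beyond the scatter. Also open, going by these compounds, is whether methoxy would give the same result on another carbon of that ring.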